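This account rests on a few compounds, and the source may have more. Where it says the series, first, only, none or still open, it means among the compounds named here.

Measured compounds in a functional assay on the whole organism for inhibition, with Mythimna separata as the target, with a stated time of 5 days; a lower number here means that less compound is needed, a higher number that more compound is needed for the effect:

Compound 1 `Cc1ccc(-c2nnc(COc3cnn(C(C)(C)C)c(=O)c3Cl)o2)cc1` gives 19.9 ug/mL.
Compound 2 `Cc1cc(C)cc(-c2nnc(COc3cnn(C(C)(C)C)c(=O)c3Cl)o2)c1` gives a limit of > 300 ug/mL.
Compound 3 `CC(C)(C)n1ncc(OCc2nnc(-c3cccs3)o2)c(Cl)c1=O` gives a limit of > 300 ug/mL.

Compound 3 stands at the upper boundary of what this assay resolves, sharing that position with compound 2 (the limit of > 300 ug/mL in this assay, at which 2 of the 3 values shown sit). Going by the values given here, the only numeric reading in the set belongs to compound 1, so every step runs from that one point: an at least 15-fold higher number from compound 1 to compound 2 (1.17 log units; beyond the scatter) and an at least 15-fold higher number from compound 1 to compound 3 (1.17 log units; beyond the scatter), while a step that the two limits leave unreadable from compound 2 to compound 3.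

Compound 4 `CC(C)(C)n1ncc(OCc2nnc(-c3c(F)cccc3F)o2)c(Cl)c1=O` differs from compound 3 by 2,6-difluorophenyl in place of thiophen-2-yl on an aromatic carbon. Among the compounds with values here, no measured step covers this exact exchange. What the data do show is that of three groups at this carbon only 4-methylphenyl gave a readable number, and that a second six-membered carbon ring, the 3,5-dimethylphenyl of compound 2, did not. A 2,6-difluorophenyl is a third variant of the six-membered ring, and the two readable steps from compound 1 give no basis for placing it nearer to compound 1 than to compound 2. The step of an at least 1.5-fold lower number from compound 3 to compound 4 (0.17 log units; that floor lies within the scatter) is therefore expected to remain unreadable, with a limit the most likely outcome. Compound 4 is estimated at 200 ug/mL, within 25 ug/mL to 300 ug/mL, with a fair chance that this assay again reports only a limit.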

Compound 4, half-maximal effective concentration: 45.4 ug/mL
The estimate for compound 4 lay 4.4-fold (0.64 log units) above the measured number; the range from low to high includes it.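

In this assay, this aromatic carbon now carries a second group that gives a readable number, so the readable results are no longer confined to 4-methylphenyl: the exchange gives an at least 6.6-fold lower number from compound 3 to compound 4 (0.82 log units; beyond the scatter), and the same group set against 3,5-dimethylphenyl gives an at least 6.6-fold lower number from compound 2 to compound 4 (0.82 log units; beyond the scatter). The type of ring alone does not sort the series, since 2,6-difluorophenyl, 4-methylphenyl and 3,5-dimethylphenyl are all six-membered aromatic rings of carbon, and compound 2 goes against any rule that favours such a ring. 2,6-Difluorophenyl does not match 4-methylphenyl, with a 2.3-fold higher number from compound 1 to compound 4 (0.36 log units; beyond the scatter), so compound 1 keeps the lowest number of the set, while the other end of the series is still known only as a limit: the limit of > 300 ug/mL in this assay, at which 2 of the 4 values shown sit.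

As far as these compounds go, the step between compound 2 and compound 3 cannot be read, as both values are limits, so the order of thiophen-2-yl and 3,5-dimethylphenyl stays unknown. Going by these compounds alone, with only two numbers at this carbon, it also remains open how an unsubstituted phenyl, a pyridine ring or a saturated cyclohexyl ring would compare with 4-methylphenyl in this assay.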